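A few compounds are considered here, and "the series" means these few. Any claim that something is new, unique, unknown or untested is made for them only; others in the source may bear on it.

Measured compounds:
compound 1, `COc1cc(-c2cc(/C=C/C(=O)c3ccc(N)cc3)[nH]n2)cc(OC)c1OC` — 95% in a functional assay on Hs-578T cells (Homo sapiens) for cytotoxicity, read by sulforhodamine B assay, with a stated time of 48 h, tested at 0.01 uM; on this read-out higher numbers stand for a weaker effect at the one concentration tested and lower numbers for a stronger effect
compound 2, `COc1ccc(-c2cc(/C=C/C(=O)c3ccc(OC)c(OC)c3)[nH]n2)cc1` — 96% in this assay

Both compounds were tested in this assay, and both leave most of the cells alive at the single concentration used. Compound 1 gives 95%, the lower of the two numbers, but compound 2 at 96% sits only a single point away, so the two readings cannot be told apart and neither compound can be called the stronger one.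

The unmeasured compound 3, `COc1ccc(C(=O)/C=C/c2cc(-c3cc(OC)c(OC)c(OC)c3)n[nH]2)cc1OC`, is reached from compound 1 by one change: 3,4-dimethoxyphenyl in place of 4-aminophenyl on a carbonyl carbon. Within the data shown here, no pair of measured compounds differs in this way, so the size of the step is not known from any measured pair. Since both measured compounds cluster near the weak end, the step from compound 1 to compound 3 in this assay is expected to be small, a number 1 percentage points lower from compound 1 to compound 3 (within the scatter), and not beyond the scatter in either direction. Compound 3 is therefore estimated to give about 94%, within 84% to 100%.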

Compound 3, a percentage reported as activity, at one concentration (the size of the read-out at that concentration, not a potency): 98%
The estimate for compound 3 lay 4 percentage points below the measured number; the range from low to high includes it.
By their numbers in this assay, from the lowest: compounds 1, 2 and 3 (each within the scatter of the next).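

In this assay, replacing 4-aminophenyl with 3,4-dimethoxyphenyl on the carbonyl carbon gives a number 3 percentage points higher from compound 1 to compound 3 (within the scatter), the first step measured at this position. The group that leaves has 7 heavy atoms and 1 hydrogen-bond donor, while the group that enters has 10 heavy atoms and 0 hydrogen-bond donors, yet this exchange does not separate the two compounds at the single concentration tested. No supporting measurement offers an explanation for this result.

The compounds shown leave open whether a very different group at this position, such as a carboxylic acid or a longer alkyl chain, would move the reading beyond the usual scatter. They also leave open whether compound 1 and compound 3 would still match at a higher concentration, where a stronger effect might appear.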